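Piperazine aryl swap in a phthalazinone series

This account rests on a few compounds, and the source may have more. Where it says the series, first, only, none or still open, it means among the compounds named here.

Compound 1 `CCOc1ccccc1N1CCN(CCn2nc(-c3ccc(C)cc3)c3ccccc3c2=O)CC1` gives 3.9 nM in an assay on Cerebral cortex for displacement of a labelled ligand from Adrenergic receptor alpha-1 (Rattus norvegicus); on this read-out higher numbers stand for weaker inhibition and lower numbers for stronger inhibition. Compound 2 `COc1ccccc1N1CCN(CCCCn2nc(-c3ccc(C)cc3)c3ccccc3c2=O)CC1` gives 2.6 nM in this assay. Compound 3 `Cc1ccc(-c2nn(CCCCN3CCN(c4ccccc4OC(C)C)CC3)c(=O)c3ccccc23)cc1` gives 1.07 nM in this assay.

Compound 3 stands lowest of the three numbers in this assay, its nearest neighbour being compound 2 and the furthest compound 1. Compound 1 and compound 2 differ in two places at once, so their two values are simply reported side by side. Going by the values given here, the one single-point step in the set, a 2.4-fold lower number from compound 2 to compound 3 (0.39 log units; beyond the scatter), is modest and concerns only the alkyl group on the ring oxygen.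

Compound 4 `Cc1ccc(-c2nn(CCCCN3CCN(c4cccc(C(F)(F)F)c4)CC3)c(=O)c3ccccc23)cc1` is not yet measured. It differs from compound 3 by 3-(trifluoromethyl)phenyl in place of 2-isopropoxyphenyl on an amine nitrogen in a ring. Among the compounds with values here, no measured step covers this exchange: the ring oxygen that was retained across the step from compound 2 to compound 3 leaves altogether, and the three fluorine atoms enter. With nothing in the data bearing directly on it, the expectation for compound 4 rests on the value of compound 3, 1.07 nM, with a wide band around it. Compound 4 is therefore expected to show a 9.3-fold higher number from compound 3 to compound 4 (0.97 log units; beyond the scatter) in this assay, most likely a somewhat higher number, with the estimate 10 nM and a range from 2 nM to 50 nM.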

Compound 4, inhibition constant: 112 nM
Beside the measured number, compound 4's estimate is 11-fold (1.05 log units) below it; the whole stated range lies below it.
By their numbers in this assay, from the lowest: compound 3; then compounds 2 and 1 (each within the scatter of the next); then compound 4.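

Going by these compounds alone, the aryl group on the amine nitrogen in a ring matters far more in this assay than the alkyl group on the ring oxygen: replacing 2-isopropoxyphenyl with 3-(trifluoromethyl)phenyl gives a 100-fold higher number from compound 3 to compound 4 (2.02 log units; beyond the scatter), well beyond a 2.4-fold lower number from compound 2 to compound 3 (0.39 log units; beyond the scatter) seen when only that alkyl group changed. The same entering group also gives a 43-fold higher number from compound 2 to compound 4 (1.63 log units; beyond the scatter), so among these butyl-linked compounds, a large rise in the number follows the exchange from either oxygen-bearing aryl group, and the difference between methyl and isopropyl on the oxygen does not offset it. No independent measurement here accounts for the size of these steps.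

The exchange removes the ring oxygen, brings in the three fluorine atoms and moves the substituent to a different place on the ring all at once, so the compounds shown cannot assign the rise to any one of these changes. They also leave open how the number would respond to an unsubstituted phenyl group, or to a nitrile or a chlorine atom in place of the trifluoromethyl group, on the same piperazine and butyl chain.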